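A few compounds are considered here, and "the series" means these few. Any claim that something is new, unique, unknown or untested is made for them only; others in the source may bear on it.

Measured in an ADME assay on CCRF-CEM cells (Homo sapiens) for antiproliferative activity, with a stated time of 48 h; on this read-out lower numbers stand for stronger inhibition and higher numbers for weaker inhibition:
- compound 1 `C=C(Br)C(=O)Nc1ccc(/C=C/C(=O)c2ccccc2)cc1` gives 4000 nM
- compound 2 `C=C(Br)C(=O)Nc1ccc(/C=C/C(=O)c2ccc(Cl)cc2)cc1` gives 950 nM
- compound 3 `C=C(Br)C(=O)Nc1ccc(/C=C/C(=O)c2ccc(Cl)c(Cl)c2)cc1` gives 1700 nM

Compound 3 (1700 nM) lies within the scatter of compound 2 (950 nM), and both stand clear of compound 1 (4000 nM) by modest steps.

Compound 4 `C=C(Br)C(=O)Nc1ccc(/C=C/C(=O)c2ccc(I)cc2)cc1` has not been measured. It carries 4-iodophenyl in place of 3,4-dichlorophenyl on a carbonyl carbon.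

Among the compounds with values here, three measured steps bear on this change. Adding the first chloro gave a modest step (a 4.2-fold lower number from compound 1 to compound 2 (0.62 log units; beyond the scatter)). Adding the second chloro stayed within the scatter (a 1.8-fold higher number from compound 2 to compound 3 (0.25 log units; within the scatter)). The full change from phenyl to 3,4-dichlorophenyl was also modest (a 2.4-fold lower number from compound 1 to compound 3 (0.37 log units; beyond the scatter)). Within the data shown here, compound 4 keeps a single halogen on this ring, as compound 2 does, but no iodo compound has been measured, so the read-across from chloro to iodo is untested. Among the measured compounds shown here, the series shows halogenated compounds separated from compound 1 and not from each other, although it holds only two such compounds.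

In this assay no change beyond the scatter is therefore expected. The estimated step is a 1.4-fold lower number from compound 3 to compound 4 (0.15 log units; within the scatter) and would be small. For compound 4 the expected value is 1200 nM within an estimated range of 400 nM to 3500 nM as a working guess.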

Compound 4, half-maximal inhibitory concentration: 4000 nM
Compound 4: the middle estimate sits 3.3-fold (0.52 log units) below what was measured; measured number above the stated range.
By their numbers in this assay, from the lowest: compounds 2 and 3 (each within the scatter of the next); then compounds 1 and 4 (each within the scatter of the next).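

In this assay, the identity of the halogen on this ring matters, which the two chloro compounds alone could not show: iodo in place of chloro on an aromatic carbon gives a clear step (a 4.2-fold higher number from compound 2 to compound 4 (0.62 log units; beyond the scatter)), and 4-iodophenyl in place of 3,4-dichlorophenyl on the same carbonyl carbon also moves the number beyond the scatter (a 2.4-fold higher number from compound 3 to compound 4 (0.37 log units; beyond the scatter)). Iodo in place of hydrogen leaves compound 4 level with the unsubstituted phenyl of compound 1 (no change at the digits printed from compound 1 to compound 4 (within the scatter)), so halogenation alone does not separate a compound from compound 1; compounds 2 and 3 stand apart from compound 1, and compound 4 goes against any general halogen trend. Nothing available explains why chloro and iodo part here.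

Still open, on these data alone, is whether bromo or fluoro in place of the iodo of compound 4 would group with the chloro compounds or with compounds 1 and 4. Also open, as far as these compounds go, is whether a non-halogen group such as methoxy or an amine at the same ring carbon would keep the number of compound 2 or return it to that of compound 1.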